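Methyl in place of chloro on the hydroxycarbamoyl compound

The compounds below may be only part of what the source reports. "The series", "measured", "known", "first", "only" and "open" are said of these compounds alone.

- compound 1 `O=C(/C=C/c1ccc(CN2C(=O)/C(=C3\Nc4ccccc4\C3=N/O)c3cc(Cl)ccc32)cc1)NO` gives 60 nM
- compound 2 `O=C(NO)c1ccc(CN2C(=O)/C(=C3\Nc4ccccc4\C3=N/O)c3cc(Cl)ccc32)cc1` gives 50 nM
- compound 3 `COc1ccc2c(c1)/C(=C1/Nc3ccccc3/C1=N\O)C(=O)N2Cc1ccc(/C=C/C(=O)NO)cc1` gives 30 nM

In a functional assay on PC-3 cells (Homo sapiens) for cytotoxicity, read by colorimetric assay (on this read-out higher numbers stand for weaker inhibition and lower numbers for stronger inhibition), compound 2 gives 50 nM and lies within the scatter of the other two compounds. Compound 4 `Cc1ccc2c(c1)/C(=C1/Nc3ccccc3/C1=N\O)C(=O)N2Cc1ccc(C(=O)NO)cc1` carries methyl in place of chloro on an aromatic carbon. Within the data shown here, no measured compound carries this methyl, so the evidence is indirect. Replacing chloro with methoxy gave a step within the scatter (a 2.0-fold lower number from compound 1 to compound 3 (0.30 log units; within the scatter)), and hydroxycarbamoyl in place of 2-(hydroxycarbamoyl)ethenyl did the same (a 1.2-fold lower number from compound 1 to compound 2 (0.08 log units; within the scatter)). No step beyond the scatter is therefore expected in this assay, and no direction is favoured. The expected step is small (a 1.1-fold lower number from compound 2 to compound 4 (0.05 log units; within the scatter)). Compound 4 is estimated at 45 nM (expected range 20 nM to 100 nM).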

Compound 4, half-maximal inhibitory concentration: 90 nM
For compound 4 the middle estimate is 2.0-fold (0.30 log units) below the measured one, and the stated range covers the measured number.
By their numbers in this assay, from the lowest: compounds 3, 2, 1 and 4 (each within the scatter of the next, the first and the last beyond it).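

In this assay, methyl in place of chloro on an aromatic carbon of the shared core now has a direct reading on the hydroxycarbamoyl compounds (a 1.8-fold higher number from compound 2 to compound 4 (0.26 log units; within the scatter)). Together with methoxy in place of chloro on the 2-(hydroxycarbamoyl)ethenyl compounds (a 2.0-fold lower number from compound 1 to compound 3 (0.30 log units; within the scatter)), this position has now held chloro, methoxy and methyl with no listed step beyond the scatter. No measured property bears on this result.

From the compounds shown here alone, whether an amine, a carboxylic acid or a longer chain on this aromatic carbon would also stay within the scatter remains open.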